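From carboxy to methoxycarbonyl: compound 2 becomes compound 4

A few compounds are considered here, and "the series" means these few. Any claim that something is new, unique, unknown or untested is made for them only; others in the source may bear on it.

Of the compounds shown here, three have been tested in an ADME assay on BJ cells (Homo sapiens) for cytotoxicity, with a stated time of 72 h (on this read-out higher numbers stand for an effect only at larger amounts of compound and lower numbers for an effect already at smaller amounts), so far: compound 1 (`O=C(O)COc1cc(Cl)c(C(=O)Nc2cccc(-c3nc4ccccc4s3)c2)cc1[N+](=O)[O-]`), compound 2 (`Cc1ccc(-c2nc3ccccc3s2)cc1NC(=O)c1cc([N+](=O)[O-])c(N2CCC(C(=O)O)CC2)cc1Cl`) and compound 3 (`O=C(Nc1ccc(-c2ccccc2)cc1)c1cc([N+](=O)[O-])ccc1Cl`). Compound 1 gives > 25000 nM as a limit and not a number. Compound 2 gives > 25000 nM as a limit too. Compound 3 gives > 27000 nM as a limit as well. Compound 2 therefore has no exact value, and neither do the other two. Compound 4 (`COC(=O)C1CCN(c2cc(Cl)c(C(=O)Nc3cc(-c4nc5ccccc5s4)ccc3C)cc2[N+](=O)[O-])CC1`) differs from compound 2 by one change methyl in place of hydrogen on an oxygen next to a carbonyl group with methyl in place of hydrogen on an oxygen next to a carbonyl group, so carboxy becomes methoxycarbonyl. Among the measured compounds shown here, no measured pair shows this change. In this assay the estimated step of a number no higher from compound 2 to compound 4 (the limit leaves the size open) is expected to stay within the usual scatter. Compound 4 is estimated at 25000 nM with an expected range of 10000 nM to 40000 nM for its measurement.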

Compound 4, half-maximal effective concentration: > 25000 nM
Compound 4: a limit, no number; the forecaster's own chance of this, stated with the estimate: 65%; the middle value lies on the limit itself.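

Compound 2 and compound 4 each give only a limit in this assay, so no step can be read between them. The compounds shown leave open whether changing carboxy to methoxycarbonyl alters cytotoxicity at all.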